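The source may hold more compounds than are shown below. What is called first, only, known or untested is meant among the compounds shown, and "the series" means these compounds.

Compound 1 `COc1cc(NC(C)CCCNC(=O)Nc2ccc(Br)cc2)c2ncccc2c1`: 18000 nM
Compound 2 `COc1cc(NC(C)CCCNC(=O)NNC(=O)Nc2ccc(F)cc2)c2ncccc2c1`: 104000 nM
Compound 3 `COc1cc(NC(C)CCCNC(=O)Nc2ccc(F)cc2)c2ncccc2c1`: not yet measured

Both values come from a functional assay on L1210 cells (Mus musculus) for inhibition, read by MTT assay, with a stated time of 72 h; a higher number here means a weaker inhibitor, a lower number a stronger inhibitor. Of the two measured compounds, compound 2 has the higher number and is therefore the weaker inhibitor. For the measured compounds named here, its only neighbour on this scale is compound 1, and the difference between them is a 5.8-fold higher number from compound 1 to compound 2 (0.76 log units; beyond the scatter).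

The next change is 4-fluorophenyl in place of ((4-fluorophenyl)carbamoyl)amino on an amide-type nitrogen. In words, 4-fluorophenyl replaces ((4-fluorophenyl)carbamoyl)amino on an amide-type nitrogen. Going by the values given here, only one measured step bears on this change, and it concerns the same place in the molecule. That step, a 5.8-fold higher number from compound 1 to compound 2 (0.76 log units; beyond the scatter), brought in the larger group in place of 4-bromophenyl. Compound 3 loses that larger group again, so it returns to a plain aryl group like that of compound 1, which gives 18000 nM. However, 4-fluorophenyl is not 4-bromophenyl, and no measured pair isolates that swap. A drop in this assay of similar size is therefore expected, though with real uncertainty. The expected change is a 4.2-fold lower number from compound 2 to compound 3 (0.62 log units; beyond the scatter). Compound 3 is estimated at 25000 nM, with an expected range from 10000 nM to 60000 nM.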

Compound 3, half-maximal inhibitory concentration: 18000 nM
Estimate against measurement, compound 3: 1.4-fold (0.14 log units) above; low and high end bracket the measured number.
By their numbers in this assay, from the lowest: compounds 1 and 3 (each within the scatter of the next); then compound 2.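

Swapping ((4-fluorophenyl)carbamoyl)amino for 4-fluorophenyl on the amide-type nitrogen gives, in this assay, a 5.8-fold lower number from compound 2 to compound 3 (0.76 log units; beyond the scatter) with the fluoro group kept, so this pair isolates the effect of removing the carbamoylamino portion, which the earlier step could not do because it also exchanged bromo for fluoro. The swap of fluoro for bromo on the aromatic carbon gives no change at the digits printed from compound 1 to compound 3 (within the scatter) in this assay, meaning that these two halogens cannot be told apart here and that the difference seen earlier goes with the longer group on the nitrogen within these three compounds. Nothing available explains why the longer group goes with the higher number in this cell assay.

The compounds shown leave open whether the aromatic carbon tolerates something other than a halogen, such as a methoxy group, an amine or a carboxylic acid. They also leave open whether the aromatic ring on the amide-type nitrogen is needed at all, which a cyclohexyl group or a plain butyl chain in its place could test.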